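The compounds below may be only part of what the source reports. "The series", "measured", "known", "first", "only" and "open" are said of these compounds alone.

Compound 1 `CCC[C@H]1C[C@@H](O)[C@@H](O)C1`: in an ADME assay on S2 cells (Drosophila melanogaster) for cytotoxicity, read by MTT assay (a higher number here means that more compound is needed for the effect, a lower number that less compound is needed), compound 1 gives > 350000 nM, which is a limit of the assay.
Compound 2 `O=C(/C=C/[C@H]1C[C@@H](O)[C@@H](O)C1)Oc1ccccc1`: in this assay compound 2 gives > 200000 nM, again a limit.
Compound 3 `O=C(/C=C/[C@H]1C[C@@H](O)[C@@H](O)C1)Nc1ccccc1`: in this assay compound 3 gives > 200000 nM, also a limit.

Compound 3 thus stands at a limit, with no measured number; two of the three values shown sit at the limit of > 200000 nM in this assay, at which 2 of the 3 values shown sit, and the third at the limit of > 350000 nM in this assay, at which 1 of the 3 values shown sits. Compound 4 `O=C(/C=C/[C@H]1C[C@@H](O)[C@@H](O)C1)NC1CC1` differs from compound 3 in one place: cyclopropyl in place of phenyl on an amide-type nitrogen. Among the compounds with values here, no step between two measured compounds is known here, so no size of change can be read from the data. Given that compound 3 gives only a limit in this assay, compound 4 is expected to stay at or near it, with an expected step that the limit leaves unreadable from compound 3 to compound 4. The estimate for compound 4 is 250000 nM, within a range from 100000 nM to 450000 nM.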

Compound 4, half-maximal effective concentration: > 250000 nM
Compound 4 was reported as a limit (the forecaster's own chance of this, stated with the estimate: 85%); the middle value lies on the limit itself.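

Within the data shown here, compound 3 and compound 4 are both reported only as limits in this assay, so no step between them can be read. The compounds shown leave open what concentration, if any, would produce a half-maximal effect for any of them.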